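Replacing the fluoro group of compound 2 with hydrogen

A few compounds are considered here, and "the series" means these few. Any claim that something is new, unique, unknown or untested is made for them only; others in the source may bear on it.

Of the compounds shown here, two have been read so far in a functional assay on HCT-116 cells (Homo sapiens) for antiproliferative activity, read by MTT assay, with a stated time of 48 h; on this read-out lower numbers stand for stronger inhibition and higher numbers for weaker inhibition. Compound 1 (`CC(CCO)n1cnc2c(Cl)ncnc21`) gives > 50000 nM, which is a limit of the assay and not a number. Going by the values given here, compound 2 (`CCC(CCO)n1cnc2c(Cl)nc(F)nc21`) gives 18900 nM, the only true number, so its standing rests on a single comparison with compound 1.

Compound 3 (`CCC(CCO)n1cnc2c(Cl)ncnc21`) differs from compound 2 as follows: hydrogen in place of fluoro on an aromatic carbon. The hydrogen takes the place of fluoro on an aromatic carbon between two ring nitrogen atoms.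

Among the compounds with values here, no measured step exists to size this change in this assay. A modest weakening is expected, with some chance of no change beyond the scatter, and a 1.7-fold higher number from compound 2 to compound 3 (0.23 log units; within the scatter) is the estimated step. For compound 3 the estimated value is 32000 nM, with an expected range of 14000 nM to 70000 nM.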

Compound 3, half-maximal inhibitory concentration: > 50000 nM
Compound 3 was reported as a limit; the forecaster's own chance of this, stated with the estimate: 35%; middle value at least 1.5-fold (0.19 log units) away from the limit.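

In this assay, going by these compounds alone, hydrogen in place of fluoro on an aromatic carbon between two ring nitrogen atoms gives an at least 2.6-fold higher number from compound 2 to compound 3 (0.42 log units; beyond the scatter), so at this position the number measured for compound 2 depends on the fluoro group, a link that the earlier compounds could not show. On these data alone, compound 3 stands at a limit and not a number, so the full size of this step stays unknown: the limit of > 50000 nM in this assay, at which 2 of the 3 values shown sit. The step from compound 1 to compound 3, methyl in place of hydrogen on the saturated chain, cannot be read, as both ends are limits.

Still open, as far as these compounds go, is whether an amine or a nitrile at this position would keep or improve on the number of compound 2. Also open, from the compounds shown here alone, is how a longer chain in place of the present one would act in this assay while the fluoro group stays.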